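This account rests on a few compounds, and the source may have more. Where it says the series, first, only, none or still open, it means among the compounds named here.

Compound 1 `Cc1cc(C)c(S(=O)(=O)N2CCC(c3ccccc3)CC2)c(C)c1`: > 5000 nM
Compound 2 `CC1CCN(C2CCN(S(=O)(=O)c3cc(Cl)cc(Cl)c3)CC2)CC1`: 3400 nM

In a functional assay on DLD-1 cells (Homo sapiens) for antiproliferative activity, read by CellTiter-Glo, with a stated time of 72 h (on this read-out higher numbers stand for weaker inhibition and lower numbers for stronger inhibition), compound 1 gives only a limit, > 5000 nM, so where it stands is known just to that edge (the limit of > 5000 nM in this assay, at which 1 of the 2 values shown sits). Compound 2 gives 3400 nM. Compound 3 `Cc1cc(C)c(S(=O)(=O)N2CCC(N3CCC(C)OC3)CC2)c(C)c1` differs from compound 1 by a group of 7 heavy atoms (5 carbon, 1 nitrogen, 1 oxygen; one six-membered non-aromatic ring with 2 hetero atoms) in place of a group of 6 heavy atoms (6 carbon; one six-membered aromatic ring of carbon only), on a saturated ring carbon. Among the measured compounds shown here, no step between measured compounds speaks to this change, so in this assay the expected step of an at least 1.1-fold lower number from compound 1 to compound 3 (0.04 log units; that floor lies within the scatter) is small, if any, beyond the scatter. Compound 3 is therefore estimated at 4500 nM, within 1500 nM to 15000 nM, with a fair chance that again only a limit is reported.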

Compound 3, half-maximal inhibitory concentration: 92 nM
Compound 3: middle estimate off by 49-fold (1.69 log units), on the high side; the whole stated range lies above it.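

In this assay, the ring with 2 hetero atoms in place of phenyl, on the saturated ring carbon, gives an at least 54-fold lower number from compound 1 to compound 3 (1.73 log units; beyond the scatter). Among the compounds shown here, this is the first step at this place, and it shows that the group there can move the read-out well beyond the scatter, though not why. The true size of the step stays unknown, because compound 1 gives only a limit: the limit of > 5000 nM in this assay, at which 1 of the 3 values shown sits.

On these data alone, whether the ring oxygen, the methyl or the ring nitrogen carries the gain remains open. So does whether a morpholine or a dimethylamino group at this place would do the same.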